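The compounds below may be only part of what the source reports. "The series", "measured", "known", "first", "only" and "open" are said of these compounds alone.

Compound 1, `CC(C)c1noc(N2CCN(C(=O)[C@@H]3CCCN(S(=O)(=O)c4ccc(S(=O)(=O)C(C)C)cc4)C3)CC2)n1`: > 10000 nM
Compound 2, `CCOC(=O)[C@@H]1C[C@@H](O)CN(S(=O)(=O)c2ccc(S(=O)(=O)N(CC)CC)cc2)C1`: > 10000 nM

Of the compounds shown here, two have been tested in a functional assay on MIA PaCa-2 cells (Homo sapiens) for inhibition, read by MTT assay, with a stated time of 3 days; a lower number here means a stronger inhibitor, a higher number a weaker inhibitor. Compound 1 gives > 10000 nM, which is a limit of the assay rather than a measured number. Compound 2 gives > 10000 nM in this assay, again a limit and not a number. Where compound 1 stands can therefore be told only roughly: it sits at the limit of > 10000 nM in this assay, at which 2 of the 2 values shown sit, and no change from it to another measured compound has been followed.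

The next compound, compound 3, `CCN(CC)S(=O)(=O)c1ccc(S(=O)(=O)N2CCC[C@@H](C(=O)N3CCN(c4nc(C(C)C)no4)CC3)C2)cc1`, differs from compound 1 in one place: diethylamino in place of isopropyl on a sulfonyl sulfur. The group that enters is also present in compound 2, which itself reaches only the limit in this assay.

Among the measured compounds shown here, no measured step covers this change, so its size can only be guessed. With both measured compounds at the limit, no shift beyond the usual scatter is expected, and the step that the limit leaves unreadable from compound 1 to compound 3 is expected to be small in either direction. Compound 3 is therefore estimated at 12000 nM, with a range from 4000 nM to 40000 nM, and most likely reported again as a limit.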

Compound 3, half-maximal inhibitory concentration: > 10000 nM
Compound 3: only a limit was reported; the forecaster's own chance of this, stated with the estimate: 80%; the middle value is on the limit's open side.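

In this assay compound 3 gives > 10000 nM, again a limit of the assay and not a number. The change from compound 1 to compound 3 therefore cannot be read as a step. The compounds shown leave open how diethylamino and isopropyl on the sulfonyl sulfur compare, and whether any such compound gives a measured number in this assay.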